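A few compounds are considered here, and "the series" means these few. Any claim that something is new, unique, unknown or untested is made for them only; others in the source may bear on it.

Measured so far, with values from a functional assay on cells (Cancer cell lines, Homo sapiens) for inhibition, with a stated time of 48 h (a lower number here means a stronger inhibitor of growth, a higher number a weaker inhibitor of growth), as follows:
Compound 1 `COc1cc2c(cc1C)N(C)C(=O)/C2=C/c1c(Cl)[nH]c2ccccc12` gives 300 nM
Compound 2 `COc1cc2c(cc1C)NC(=O)/C2=C/c1c[nH]c2ccccc12` gives 11800 nM
Compound 3 `COc1cc2c(/C=C3/C(=O)N(C)c4ccccc43)c[nH]c2cc1C` gives 1780 nM

Among these three, compound 3 at 1780 nM holds the middle place. Compound 1 shows a lower number and compound 2 a higher one, and both gaps lie beyond the scatter.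

Compound 4 `COc1cc2c(/C=C3/C(=O)N(C)c4ccc(O)cc43)c[nH]c2cc1C` is compound 3 with hydroxy in place of hydrogen on an aromatic carbon and has not yet been measured. That carbon belongs to a six-membered aromatic ring of carbon only, part of a fused or bridged system of two rings, and it is meta to a fused ring and para to a fused ring.

Among the compounds with values here, no measured pair isolates this change, so the series gives no direct size for it. Only a small change in this assay is expected, none beyond the scatter. The expected result is a 1.1-fold higher number from compound 3 to compound 4 (0.05 log units; within the scatter) on this estimate. For compound 4 the estimated value is 2000 nM with an expected range from 600 nM to 7000 nM in this read-out.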

Compound 4, concentration for 50% growth inhibition: 2750 nM
Compound 4: middle estimate off by 1.4-fold (0.14 log units), on the low side, and the stated range covers the measured number.
By their numbers in this assay, from the lowest: compound 1; then compounds 3 and 4 (each within the scatter of the next); then compound 2.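

In this assay, hydroxy in place of hydrogen on an aromatic carbon gives a 1.5-fold higher number from compound 3 to compound 4 (0.19 log units; within the scatter), so compound 3 and compound 4 cannot be told apart in this read-out. Within the data shown here, this is the first pair that differs in one place, and it shows that this carbon, meta to a fused ring and para to a fused ring, can carry a hydroxy group with no separation from compound 3 beyond the scatter. Nothing at hand explains why the hydroxy group has so small a step.

As far as these compounds go, whether an amine or a carboxylic acid on this carbon would also stay within the scatter of compound 3 remains open. Also open, from the compounds shown here alone, is whether hydroxy would give a similarly small step on the other carbons of this ring or on the core of compound 1.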